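This account rests on a few compounds, and the source may have more. Where it says the series, first, only, none or still open, it means among the compounds named here.

Compound 1 `Cc1c(C2CC2)nc2ccc(NC(=O)COc3ccc(OC(F)(F)F)cc3)cn12` opens the set: in an assay on CHO cells for displacement of a labelled ligand from melanin-concentrating hormone receptor 1 (Rattus norvegicus), read by scintillation counting, with a stated time of 1 h (a higher number here means a weaker inhibitor, a lower number a stronger inhibitor), compound 1 gives 6.3 nM. Compound 2 `Cc1c(C2CC2)nc2ccc(-n3ccc(OCc4ccc(F)cc4)cc3=O)cn12` shares the core but carries another substituent on the pyridine-like edge; in this assay compound 2 gives 28 nM, the higher of the two numbers read in this run, with compound 1 the nearer and lower. Going by the values given here, no single-point step joins compounds 1 and 2, so only their two values are set side by side. Compound 3 `Cc1c(CO)nc2ccc(-n3ccc(OCc4ccc(F)cc4)cc3=O)cn12` reaches only a limit of the assay: in this assay compound 3 gives > 1000 nM, which is the limit of > 1000 nM in this assay, at which 1 of the 3 values shown sits. Among the compounds with values here, the one measured single-point step, an at least 35-fold higher number from compound 2 to compound 3 (1.55 log units; beyond the scatter), is large.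

Compound 4 `Cc1c(C2CC2)nc2ccc(-n3ccc(OCc4cncnc4)cc3=O)cn12` is not yet measured. It differs from compound 2 by pyrimidin-5-yl in place of 4-fluorophenyl on a saturated chain carbon bound to an oxygen on an aromatic ring. Within the data shown here, the measured step from compound 2 to compound 3 concerns the cyclopropyl on an aromatic carbon and leaves the 4-fluorobenzyl untouched, so no measured step bears directly on the change to compound 4, and nothing in the set fixes the size of an aryl swap on the saturated chain carbon. For compound 4 a modest rise in the number is expected, the step reading a 2.1-fold higher number from compound 2 to compound 4 (0.33 log units; beyond the scatter). Compound 4 is expected to give 60 nM in this assay, within a range from 15 nM to 300 nM.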

Compound 4, half-maximal inhibitory concentration: > 1000 nM
Compound 4: no number, only a limit (the forecaster's own chance of this, stated with the estimate: 5%); middle value at least 16-fold (1.22 log units) away from the limit.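

Up to this point only the cyclopropyl had been varied, and the 4-fluorobenzyl had stayed untouched; pyrimidin-5-yl in place of 4-fluorophenyl on a saturated chain carbon bound to an oxygen on an aromatic ring now reads as an at least 35-fold higher number from compound 2 to compound 4 (1.55 log units; beyond the scatter) in this assay, so this position too does not accept every six-membered aromatic ring. The result for compound 4 is a limit of the assay and not a number, so the true size of this step cannot be read. Two single changes from compound 2, one at the cyclopropyl and one at the 4-fluorophenyl, now end at the same limit, and the two changes cannot be ranked against each other: the limit of > 1000 nM in this assay, at which 2 of the 4 values shown sit.

The compounds shown do not separate the loss of the fluorine from the entry of the two ring nitrogens, a question that a plain phenyl or a pyridin-3-yl on the same chain carbon would address. They also leave open how a longer chain carrying the 4-fluorophenyl would read, or an amine placed on that ring.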